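Cyclopentenyl ester in place of the pyrrolidinyl ester

The source may hold more compounds than are shown below. What is called first, only, known or untested is meant among the compounds shown, and "the series" means these compounds.

The series shares one core with a variable group on an aromatic carbon. Compound 1 `COC(=O)C1=C(c2ccc(CNc3nccc(C)c3NC(=O)CC#N)cc2)CCCC1` carries the 2-(methoxycarbonyl)cyclohex-1-en-1-yl group and gives 35 nM in an assay on isolated protein for binding affinity to B1 bradykinin receptor (Homo sapiens); a lower number here means a stronger inhibitor, a higher number a weaker inhibitor. Compound 2 `COC(=O)C1CCCN1c1ccc(CNc2nccc(C)c2NC(=O)CC#N)cc1` carries the 2-(methoxycarbonyl)pyrrolidin-1-yl group instead. In this assay compound 2 reaches only the limit of the measurement, > 5000 nM; it is a limit and not a number, so compound 2 stands at the weak end of the numbers known, with no value of its own. Compound 3 `COC(=O)C1C2CCC(C2)C1c1ccc(CNc2nccc(C)c2NC(=O)CC#N)cc1` carries the bicyclic 2-(methoxycarbonyl)bicycloheptyl ester and gives 730 nM in this assay.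

Among the compounds with values here, the one measured step that bears on the next change is an at least 140-fold higher number from compound 1 to compound 2 (2.15 log units; beyond the scatter), which shows that the limit of > 5000 nM in this assay, at which 1 of the 3 values shown sits, appears when the pyrrolidinyl ester replaces the carbocyclic ester.

Compound 4 `COC(=O)C1=C(c2ccc(CNc3nccc(C)c3NC(=O)CC#N)cc2)CCC1` is the next compound. 2-(methoxycarbonyl)cyclopent-1-en-1-yl in place of 2-(methoxycarbonyl)pyrrolidin-1-yl on an aromatic carbon This change reverses the direction of the measured step, returning to a carbocyclic unsaturated ester with a ring one carbon smaller than in compound 1. A large step downward in this assay is therefore expected, an at least 83-fold lower number from compound 2 to compound 4 (1.92 log units; beyond the scatter), beyond the scatter. Compound 4 is estimated at 60 nM in this assay, with a range of 15 nM to 300 nM.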

Compound 4, inhibition constant: 126 nM
Compound 4: the middle estimate sits 2.1-fold (0.32 log units) below what was measured, within the range that was stated.
By their numbers in this assay, from the lowest: compound 1; then compound 4; then compound 3. At a limit, above all of these: compound 2.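

In this assay, the carbon-only five-membered ring of compound 4 restores a measurable value where the pyrrolidinyl ester of compound 2 gives none, with an at least 39-fold lower number from compound 2 to compound 4 (1.59 log units; beyond the scatter), so ring size alone does not separate these two esters. This step gives only a minimum size, as the value of compound 2 is a limit of the assay and not a number: the limit of > 5000 nM in this assay, at which 1 of the 4 values shown sits. Between the two unsaturated carbocyclic esters, going from the six-membered to the five-membered ring gives a modest but real change, with a 3.6-fold higher number from compound 1 to compound 4 (0.56 log units; beyond the scatter), so ring size does register at this position on the aromatic carbon.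

Compound 2 and compound 4 differ both in the ring nitrogen and in the ring double bond, and the compounds shown do not tell which of the two accounts for the step between them. Also open, on these data alone, is how this position responds to a saturated cyclopentyl ester, a seven-membered cycloheptenyl ester, or a free carboxylic acid in place of the methyl ester.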